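The compounds below may be only part of what the source reports. "The series", "measured", "known", "first", "only" and "open" are said of these compounds alone.

Working notes on the series, read in a functional assay on HL-60 cells (Homo sapiens) for antiproliferative activity, with a stated time of 72 h; on this read-out higher numbers stand for weaker inhibition and lower numbers for stronger inhibition. Going by the values given here, compound 1 `OC[C@H]1O[C@@H](n2cnc3c(NCc4ccc(Cl)cc4Cl)ncnc32)[C@H](O)[C@@H]1O` gives 96300 nM, and compound 2 `COc1ccc(CNc2ncnc3c2ncn3[C@@H]2O[C@H](CO)[C@@H](O)[C@H]2O)c(OC)c1` gives 39000 nM, the lower of the two numbers so far. Compound 3 `OC[C@H]1O[C@@H](n2cnc3c(NCc4c(F)ccc(F)c4F)ncnc32)[C@H](O)[C@@H]1O` has not been measured. Its change from compound 2 is 2,3,6-trifluorophenyl in place of 2,4-dimethoxyphenyl on a saturated chain carbon bound to a nitrogen on an aromatic ring. Among the compounds with values here, the only measured guide is a 2.5-fold lower number from compound 1 to compound 2 (0.39 log units; beyond the scatter), a modest step beyond the scatter that came with 2,4-dimethoxyphenyl replacing 2,4-dichlorophenyl. Compound 3 again loses the 2,4-dimethoxyphenyl for a halogen-bearing ring, so a modest move back towards a higher number is expected in this assay, though no trifluorophenyl has been tested. The expected step is a 2.1-fold higher number from compound 2 to compound 3 (0.31 log units; beyond the scatter). For compound 3 the estimated value is 80000 nM, with an expected range of 30000 nM to 200000 nM.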

Compound 3, half-maximal inhibitory concentration: 13000 nM
Compound 3: middle estimate off by 6.2-fold (0.79 log units), on the high side, and the stated range ends above it.
By their numbers in this assay, from the lowest: compound 3; then compound 2; then compound 1.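

In this assay, the ring on the saturated chain carbon bound to a nitrogen on an aromatic ring does not sort simply into halogen-bearing against methoxy-bearing: 2,3,6-trifluorophenyl gives a 3.0-fold lower number from compound 2 to compound 3 (0.48 log units; beyond the scatter), and a 7.4-fold lower number from compound 1 to compound 3 (0.87 log units; beyond the scatter). The two halogen-bearing rings therefore stand at opposite ends of the three numbers, with the 2,4-dimethoxyphenyl of compound 2 between them, so the presence of a halogen alone does not place a compound in this series. Nothing available here explains this order.

The kind of halogen, the number of substituents and their places all change together between compound 1 and compound 3, so the compounds shown cannot separate these factors. A 2,4-difluorophenyl ring would test the halogen with the substitution places of compound 1 kept, and an unsubstituted phenyl ring would give a baseline for all three.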